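The source may report more compounds than this note shows. Statements on the series, on what has been measured and on what is new or still open speak of the compounds shown alone.

In a functional assay on HCC 2998 cells (Homo sapiens) for inhibition, read by sulforhodamine B assay, with a stated time of 48 h, tested at 10 uM (on this read-out higher numbers stand for more inhibition at the one concentration tested (going by the name of the read-out) and lower numbers for less inhibition), compound 2 `c1cn2cc(-c3ccc4c(c3)ncn4C3CCCCC3)nc(-c3ccc4ncn(C5CCCCC5)c4c3)c2n1` gives 15.5%. Compound 1 `CCc1ccc(-c2cn3ccnc3c(-c3ccc4ncn(Cc5ccccc5)c4c3)n2)cc1` gives 25.2% in this assay, a gap that falls within the usual scatter, so the two are not told apart. Compound 3 `c1ccc(Cn2cnc3ccc(-c4nc(-c5ccc6c(c5)ncn6C5CCCCC5)cn5ccnc45)cc32)cc1` differs from compound 2 in one place: benzyl in place of cyclohexyl on an aromatic nitrogen. Going by the values given here, no step between measured compounds isolates this change, and compound 1, which also carries a benzyl, sits within the scatter of compound 2, so a step of a number 4.5 percentage points higher from compound 2 to compound 3 (within the scatter) of no size beyond the scatter is expected. Compound 3 is therefore estimated at 20%, with a range from 8% to 35%.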

Compound 3, a percentage reported as inhibition, at one concentration (the size of the read-out at that concentration, not a potency): -88%
Compound 3: middle estimate off by 108 percentage points, on the high side, outside the stated range (below it).
By their numbers in this assay, from the lowest: compound 3; then compounds 2 and 1 (each within the scatter of the next).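

In this assay, benzyl in place of cyclohexyl on this aromatic nitrogen proves far from neutral, with a number 103.5 percentage points lower from compound 2 to compound 3 (beyond the scatter) for this single change. Compound 3 reads -88% even though its other aromatic nitrogen keeps its cyclohexyl, so the reading falls below zero and not merely towards it. Nothing available here accounts for this step.

On these data alone, it remains open how a methyl, a longer alkyl chain or an aminoethyl chain on this nitrogen would read. Whether benzyl has the same effect on the other aromatic nitrogen also stays unresolved.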